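Indole carboxamide piperazinone series: solubility notes, compound 4

The source may report more compounds than this note shows. Statements on the series, on what has been measured and on what is new or still open speak of the compounds shown alone.

Measured so far:
compound 1 `COc1cccc(CN2C(=O)CN(C(=O)c3cc4cc(OC)ccc4[nH]3)C[C@@H]2COCc2ccccc2)c1` 11700 nM
compound 2 `O=C(c1cc2cc(C3CC3)ccc2[nH]1)N1CC(=O)N(Cc2ccccc2)[C@@H](CN2CCC(F)CC2)C1` 12400 nM
compound 3 `COc1ccc2[nH]c(C(=O)N3CC(=O)N(Cc4ccc[nH]4)[C@@H](Cc4ccccc4)C3)cc2c1` 38400 nM

In a physicochemical assay for solubility, read by spectrophotometry, in phosphate buffer, with a stated time of 2 h, at pH 7.4 (on this read-out higher numbers stand for higher solubility and lower numbers for lower solubility), compound 1 gives 11700 nM, which is the low end of the three numbers. Compound 2 gives 12400 nM, a gap from compound 1 that sits within the usual scatter, so the two are not separated. Compound 3 gives 38400 nM, a gap from compound 1 that lies beyond the scatter. Among the measured compounds shown here, no pair of these three differs in only one place, so no single-change step has been read directly.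

Compound 4 `COc1cccc(CN2C(=O)CN(C(=O)c3cc4cc(OC)ccc4[nH]3)C[C@@H]2Cc2ccccn2)c1` is the next one to be measured in this assay. It differs from compound 1 in one place: pyridin-2-yl in place of benzyloxy on a saturated chain carbon bound to a saturated ring carbon. The change removes two heavy atoms and brings a ring nitrogen in place of the ether oxygen, while keeping one hydrogen-bond acceptor. For the measured compounds named here, with no directly comparable step among the measured compounds, the expectation rests on compound 1 alone. The step is expected to be modest and upward, a 2.1-fold higher number from compound 1 to compound 4 (0.33 log units; beyond the scatter), but it could fall within the scatter. Compound 4 is therefore expected to give about 25000 nM, in a range from 9000 nM to 70000 nM.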

Compound 4, solubility: 57900 nM
Compound 4: middle estimate off by 2.3-fold (0.36 log units), on the low side, and the stated range covers the measured number.
By their numbers in this assay, from the lowest: compounds 1 and 2 (each within the scatter of the next); then compounds 3 and 4 (each within the scatter of the next).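

In this assay, among the compounds shown here, pyridin-2-yl in place of benzyloxy on a saturated chain carbon bound to a saturated ring carbon gives the first single-change step, a 4.9-fold higher number from compound 1 to compound 4 (0.69 log units; beyond the scatter). A change confined to this position, with the rest of compound 1 held fixed, therefore moves the number beyond the usual scatter. The counts of hydrogen-bond donors and acceptors are the same on both sides of the step, and no measurement on hand accounts for its size.

The compounds shown leave open whether the step belongs to the incoming ring nitrogen or to the loss of the ether oxygen, since both change at once. On these data alone, how this position would read with an amine such as morpholin-4-yl, or with a carboxylic acid, also remains open.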